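A few compounds are considered here, and "the series" means these few. Any claim that something is new, unique, unknown or untested is made for them only; others in the source may bear on it.

Compound 1 `O=C1/C(=C/c2ccc(Cl)cc2)CN(C(=O)CCSCCO)C/C1=C\c1ccc(Cl)cc1` was tested in a functional assay on HSC-2 cells (Homo sapiens) for cytotoxicity, read by MTT assay, with a stated time of 48 h (a lower number here means that less compound is tolerated, a higher number that more compound is tolerated), where compound 1 gives 660 nM. Compound 2 `O=C1/C(=C/c2ccc(Cl)cc2)CN(C(=O)CCSCCS(=O)(=O)O)C/C1=C\c1ccc(Cl)cc1` differs from it in one place: sulfo in place of hydroxy on a saturated chain carbon, two bonds along the chain from a sulfur. In this assay compound 2 gives 29700 nM, so that the step of a 45-fold higher number from compound 1 to compound 2 (1.65 log units; beyond the scatter) shows the sulfo group being tolerated at far higher concentration than the hydroxy group. Compound 3 `O=C1/C(=C/c2ccc([N+](=O)[O-])cc2)CN(C(=O)CCSCCO)C/C1=C\c1ccc([N+](=O)[O-])cc1` carries the same hydroxy-ended side chain as compound 1 on a different core; how the two cores differ is not broken down here. In this assay compound 3 gives 390 nM, a value within the usual scatter of the value of compound 1, so the two cannot be told apart. Compound 4 `O=C1/C(=C/c2ccc([N+](=O)[O-])cc2)CN(C(=O)CCSCCS(=O)(=O)O)C/C1=C\c1ccc([N+](=O)[O-])cc1` has not yet been measured. It stands to compound 3 as compound 2 stands to compound 1, by the same change: sulfo in place of hydroxy on a saturated chain carbon, two bonds along the chain from a sulfur. Since the earlier step of a 45-fold higher number from compound 1 to compound 2 (1.65 log units; beyond the scatter) was large, a step of similar size is expected here, a 38-fold higher number from compound 3 to compound 4 (1.59 log units; beyond the scatter), resting on that single precedent. On this basis compound 4 is estimated to give about 15000 nM in this assay, most likely between 4000 nM and 60000 nM.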

Compound 4, half-maximal cytotoxic concentration: 4730 nM
Compound 4: the middle estimate sits 3.2-fold (0.50 log units) above what was measured, and the stated range covers the measured number.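

In this assay, sulfo in place of hydroxy again gives a higher number (a 12-fold higher number from compound 3 to compound 4 (1.08 log units; beyond the scatter)), so the direction of the change carries over from one core to the other. Its size does not carry over unchanged, and the gap between the two steps is larger than the usual scatter would allow: the same change on two cores in this assay, a 45-fold higher number (1.65 log units; beyond the scatter) from compound 1 to compound 2 and a 12-fold higher number (1.08 log units; beyond the scatter) from compound 3 to compound 4, 3.7-fold (0.57 log units) apart, beyond the scatter of two such steps. This shows that the core matters to how large the step is, but two pairs of compounds do not reveal what in the cores sets the size, nor what the change would do on a third core.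

The compounds shown leave open whether a similar step would appear with other groups at the end of the chain, such as a carboxylic acid or an amine, or with a longer chain between the sulfur and the sulfo group. They also leave open how the step would behave on a core carrying methoxy groups in place of the chloro or nitro groups.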